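Swapping 1-ethoxyethyl for 5-carboxypentyl on an oxygen

The source may report more compounds than this note shows. Statements on the series, on what has been measured and on what is new or still open speak of the compounds shown alone.

In a functional assay on FM3A cells (Mus musculus) for cytotoxicity (on this read-out higher numbers stand for an effect only at larger amounts of compound and lower numbers for an effect already at smaller amounts), compound 1 (`CCCCOOC1(OOC)CCCCCCCCCCC1`) gives 20000 nM, compound 2 (`COOC1(OOC(C)(C)OC)CCCCCCCCCCC1`) gives 7300 nM and compound 3 (`CCOC(C)OOC1(OOC)CCCCCCCCCCC1`) gives 12000 nM. Compound 3 thus sits within the scatter of both others, with a 1.7-fold lower number from compound 1 to compound 3 (0.22 log units; within the scatter) and a 1.6-fold higher number from compound 2 to compound 3 (0.22 log units; within the scatter). Only a 2.7-fold lower number from compound 1 to compound 2 (0.44 log units; beyond the scatter) goes beyond the scatter, and it is modest.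

Compound 4 (`COOC1(OOCCCCCC(=O)O)CCCCCCCCCCC1`) carries 5-carboxypentyl in place of 1-ethoxyethyl on an oxygen. Among the measured compounds shown here, no measured compound holds a carboxy group, so the data cannot speak to that feature directly. The nearest guide is the butyl group of compound 1, the closest measured match to the entering chain, and a 1.7-fold lower number from compound 1 to compound 3 (0.22 log units; within the scatter) shows only a small difference. All three measured groups also stay close in this assay, the largest step being a 2.7-fold lower number from compound 1 to compound 2 (0.44 log units; beyond the scatter).

A small rise towards the number of compound 1 is therefore expected, with no clear shift beyond the scatter. The expected change is a 1.5-fold higher number from compound 3 to compound 4 (0.18 log units; within the scatter). Compound 4 is estimated at 18000 nM, with an expected range from 6000 nM to 50000 nM.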

Compound 4, half-maximal effective concentration: 14000 nM
The estimate for compound 4 lay 1.3-fold (0.11 log units) above the measured number; the range from low to high includes it.
By their numbers in this assay, from the lowest: compounds 2, 3, 4 and 1 (each within the scatter of the next, the first and the last beyond it).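

In this assay, among the compounds shown here, the place on an oxygen whose other neighbours are oxygen now takes 5-carboxypentyl, the first group here to bring a carboxy group and a hydrogen-bond donor, with no step beyond the scatter: a 1.2-fold higher number from compound 3 to compound 4 (0.07 log units; within the scatter) and a 1.9-fold higher number from compound 2 to compound 4 (0.28 log units; within the scatter). Extending the butyl chain with carboxymethyl in place of hydrogen on a saturated chain carbon also stays within the scatter, with a 1.4-fold lower number from compound 1 to compound 4 (0.15 log units; within the scatter). No evidence is available on what lies behind these small steps.

The compounds shown leave open what an amine or a longer chain would give on this oxygen. From the compounds shown here alone, it also remains open whether the carboxylic acid itself counts for anything, as a plain hexyl chain or a methyl ester in the same place would be needed to separate it from chain length.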